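The source may hold more compounds than are shown below. What is called first, only, known or untested is meant among the compounds shown, and "the series" means these compounds.

Compound 1 `CC(C)C(/C=C1\NC(=O)NC1=O)c1ccc(-c2ccc3cccc(F)c3c2)[nH]c1=O` is the reference point of this small set. In a functional assay on CHO cells for antagonist activity at prostaglandin E2 receptor EP3 subtype (Homo sapiens), read by cAMP accumulation, with a stated time of 30 min (on this read-out higher numbers stand for weaker inhibition and lower numbers for stronger inhibition), compound 1 gives 87 nM, which is the higher of the two numbers available here. Within the data shown here, compound 3 `O=C1NC(=O)/C(=C/C(c2ccc(-c3ccc4cccc(F)c4c3)[nH]c2=O)C2CC2)O1`, which carries a different five-membered ring and a cyclopropyl in place of the isopropyl, gives in this assay 33 nM, a lower number than compound 1 by a margin that lies beyond the usual scatter; since two parts of the structure differ at once, the two values show only that compound 3 sits lower, not which part accounts for it. Compound 2 `CCC(/C=C1\OC(=O)NC1=O)(CC)c1ccc(-c2ccc3cccc(C(C)C)c3c2)[nH]c1=O` has no result in this assay: "not determined" (no result reported).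

Compound 4 `CC(C)C(/C=C1\SC(=O)NC1=O)c1ccc(-c2ccc3cccc(F)c3c2)[nH]c1=O` differs from compound 1 in a single place: a group of 8 heavy atoms (4 carbon, 1 nitrogen, 2 oxygen, 1 sulfur; one five-membered non-aromatic ring with 2 hetero atoms) in place of a group of 8 heavy atoms (4 carbon, 2 nitrogen, 2 oxygen; one five-membered non-aromatic ring with 2 hetero atoms), on a saturated chain carbon bound to an aromatic carbon and a saturated chain carbon. Among the measured compounds shown here, no measured pair in this set isolates such a change, so any expectation rests on compound 1 alone together with the observation that compound 3, with its own different ring, gives 33 nM. The step from compound 1 to compound 4 in this assay is therefore expected to be small, at most a modest move toward a lower number, and it may well stay within the scatter, as a 1.6-fold lower number from compound 1 to compound 4 (0.20 log units; within the scatter) indicates. On that basis compound 4 is estimated at 55 nM in this assay, with a likely range from 20 nM to 150 nM.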

Compound 4, half-maximal inhibitory concentration: 27 nM
Estimate against measurement, compound 4: 2.0-fold (0.31 log units) above, and the stated range covers the measured number.
By their numbers in this assay, from the lowest: compounds 4 and 3 (each within the scatter of the next); then compound 1.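

Among these compounds, exchanging the ring of compound 1 for the sulfur-containing ring of compound 4, on a saturated chain carbon bound to an aromatic carbon and a saturated chain carbon, gives a 3.2-fold lower number from compound 1 to compound 4 (0.51 log units; beyond the scatter) in this assay; this is the first change in the set made in a single place, and it shows that the number at this position responds to the identity of the ring even when the rest of the structure stays the same. The two rings have the same size and the same count of 8 heavy atoms, with a sulfur entering and a nitrogen leaving, and the hydrogen-bonding count shifts from 2 hydrogen-bond donors, 2 hydrogen-bond acceptors to 1 hydrogen-bond donor, 3 hydrogen-bond acceptors. No measurement on these rings is available to connect either difference to the step.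

As far as these compounds go, it remains open how the ring of compound 3 would compare with these two rings on the isopropyl-bearing structure, and whether the cyclopropyl group would change the number when paired with the sulfur-containing ring. From the compounds shown here alone, it is also open whether a carboxylic acid in place of the ring, or a longer chain such as n-butyl in place of the isopropyl, would keep a number in this range.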